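The source may report more compounds than this note shows. Statements on the series, on what has been measured and on what is new or still open speak of the compounds shown alone.

Among the measured compounds shown here, compound 3 `COc1ccc(C(=O)/C=C/c2ccc(OCc3cn(Cc4cccc(Br)c4)nn3)cc2)cc1` is the compound with the highest number among the three measured so far: in a functional assay on MIA PaCa-2 cells (Homo sapiens) for inhibition, read by MTT assay, with a stated time of 48 h, tested at 10 uM (on this read-out lower numbers stand for less inhibition of growth and higher numbers for more inhibition of growth at the one concentration tested), compound 3 gives 50%. The nearest compound is compound 1 `O=C(/C=C/c1ccc(OCc2cn(Cc3cccc(Br)c3)nn2)cc1)c1ccc(Br)cc1`, which in this assay gives 43%; the gap from compound 1 to compound 3 is a number 7 percentage points higher from compound 1 to compound 3 (within the scatter). The furthest is compound 2 `O=C(/C=C/c1ccc(OCc2cn(Cc3cccc(F)c3)nn2)cc1)c1ccc(Br)cc1`, which in this assay gives 34%, a gap from compound 3 that lies beyond the scatter.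

Compound 4 `COc1ccc(C(=O)/C=C/c2ccc(OCc3cn(Cc4ccc(F)cc4)nn3)cc2)cc1` differs from compound 3 by 4-fluorophenyl in place of 3-bromophenyl on a saturated chain carbon bound to an aromatic nitrogen. For the measured compounds named here, one measured step bears on this: from compound 1 to compound 2 the same halogen exchange on the same ring, fluoro in place of bromo on an aromatic carbon, gave a number 9 percentage points lower from compound 1 to compound 2 (within the scatter). Going by the values given here, no measured pair separates the move from 3-bromobenzyl to 4-fluorobenzyl from the halogen exchange itself, so the step to compound 4 is read from that one pair alone.

On this basis the step from compound 3 to compound 4 in this assay is expected to be a number 8 percentage points lower from compound 3 to compound 4 (within the scatter), a downward shift that remains within the scatter. Compound 4 is therefore expected to give about 42% in this assay, with a range from 26% to 58%.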

Compound 4, percent growth inhibition at one concentration: 6%
Compound 4: middle estimate off by 36 percentage points, on the high side; measured number outside the range, below it.
By their numbers in this assay, from the lowest: compound 4; then compounds 2, 1 and 3 (each within the scatter of the next, the first and the last beyond it).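

Among the compounds shown here, at the saturated chain carbon bound to an aromatic nitrogen, the aryl group is far less forgiving than the earlier compounds suggested: in this assay, 4-fluorophenyl in place of 3-bromophenyl gives a number 44 percentage points lower from compound 3 to compound 4 (beyond the scatter), the first large step. For the compounds shown here, the earlier exchange of fluoro for bromo on an aromatic carbon gave only a number 9 percentage points lower from compound 1 to compound 2 (within the scatter), so swapping the halogen on this ring does not by itself carry a loss of this size in the one pair that tests it; that pair has the bromo-substituted aryl ketone, whereas compound 3 and compound 4 carry the methoxy-substituted one. No measurement on hand explains the loss.

The compounds shown do not separate the identity of the halogen from its place on the ring, nor show whether the size of the step depends on the group at the other end of the molecule. A 4-bromobenzyl or an unsubstituted benzyl group at this position, paired with the methoxy-substituted aryl ketone, would bear directly on both questions.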